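The source may report more compounds than this note shows. Statements on the series, on what has been measured and on what is new or still open speak of the compounds shown alone.

Measured in a functional assay on MDA-MB-231 cells (Homo sapiens) for antiproliferative activity, read by MTT assay, with a stated time of 48 h; on this read-out higher numbers stand for weaker inhibition and lower numbers for stronger inhibition:
compound 1 `COC1=CC(=O)N(C(=O)/C=C/[C@H](C)NC(=O)[C@H](CC(C)C)N(C)C)[C@H]1Cc1ccccc1`: 57700 nM
compound 2 `COC1=CC(=O)N(C(=O)/C=C/[C@H](C)NC(=O)[C@H](CC(C)C)N(C)C)[C@@H]1Cc1ccccc1`: 94800 nM
compound 3 `CC[C@H](C)[C@H](NC(=O)OCc1ccccc1)C(=O)N[C@@H](CC(C)C)C(=O)N[C@@H](CC(C)C)C(=O)N[C@@H](C)/C=C/C(=O)N1C(=O)C=C(OC)[C@@H]1c1cn(C(=O)OC(C)(C)C)c2ccccc12`: > 100000 nM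

Compound 3 has no number in this assay: its > 100000 nM is a limit of the assay.

The next compound is compound 4 `CC[C@H](C)[C@H](NC(=O)OCc1ccccc1)C(=O)N[C@@H](CC(C)C)C(=O)N[C@@H](CC(C)C)C(=O)N[C@@H](C)/C=C/C(=O)N1C(=O)C=C(OC)[C@@H]1c1c[nH]c2ccccc12`, with hydrogen in place of tert-butoxycarbonyl on an aromatic nitrogen.

Among the compounds with values here, the one measured step, a 1.6-fold higher number from compound 1 to compound 2 (0.22 log units; within the scatter), rests on (the fact that compounds 1 and 2 differ only in the configuration as drawn), so it offers no size for this replacement. Any number obtained for compound 4 is expected to be lower than that limit because of the limit of > 100000 nM in this assay, at which 1 of the 3 values shown sits, and a second limit reading remains possible. Within the data shown here, the only numbers to lean on are those of compound 1, 57700 nM, and compound 2, 94800 nM, so the expectation is loose.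

The expected change, towards stronger inhibition, is an at least 2.0-fold lower number from compound 3 to compound 4 (0.30 log units; that floor lies within the scatter). For compound 4 the estimated value is 50000 nM, with an expected range of 10000 nM to 100000 nM.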

Compound 4, half-maximal inhibitory concentration: > 100000 nM
Compound 4 gave a limit, no number; the forecaster's own chance of this, stated with the estimate: 40%; middle value at least 2.0-fold (0.30 log units) from the limit.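

In this assay compound 3 gives > 100000 nM, a limit of the assay. Compound 4 gives > 100000 nM, also a limit, so no step can be read between the two compounds. The compounds shown leave open whether hydrogen in place of tert-butoxycarbonyl on an aromatic nitrogen changes the read-out at all.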